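Swapping an Amine Tail on a Shared Core

A few compounds are considered here, and "the series" means these few. Any claim that something is new, unique, unknown or untested is made for them only; others in the source may bear on it.

Compound 1 `CCN(CC)CCN(C)Cc1c(C(C)(C)C)nc2n(Cc3ccccc3F)c(C)c(-c3cccc(OC)c3)c(=O)n12` and compound 2 `COC(=O)C(C)(C)c1nc2n(Cc3ccccc3F)c(C)c(-c3cccc(OC)c3)c(=O)n2c1CN(C)Cc1ccccc1O` share a core but differ in several places. In an assay on isolated protein for binding affinity to Gonadotropin-releasing hormone receptor (Homo sapiens) (on this read-out higher numbers stand for weaker inhibition and lower numbers for stronger inhibition), compound 1 gives 260 nM, and compound 2 gives 490 nM; compound 1 holds the lower of the two numbers, yet the gap between them falls within the usual scatter. Compound 3 `COc1cccc(-c2c(C)n(Cc3ccccc3F)c3nc(C(C)(C)C)c(CNCc4ccccn4)n3c2=O)c1` is reached from compound 1 by a single change: ((pyridin-2-yl)methyl)amino in place of (2-(diethylamino)ethyl)(methyl)amino on a saturated chain carbon bound to an aromatic carbon. Going by the values given here, no measured pair shows this exact change, so its size is unknown. The step that the estimate below means, a 1.2-fold higher number from compound 1 to compound 3 (0.06 log units; within the scatter), is expected to stay within the scatter. Compound 3 is estimated at 300 nM, within 100 nM to 900 nM.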

Compound 3, inhibition constant: 30 nM
Beside the measured number, compound 3's estimate is 10-fold (1.00 log units) above it; measured number outside the range, below it.
By their numbers in this assay, from the lowest: compound 3; then compounds 1 and 2 (each within the scatter of the next).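

In this assay, ((pyridin-2-yl)methyl)amino in place of (2-(diethylamino)ethyl)(methyl)amino gives an 8.7-fold lower number from compound 1 to compound 3 (0.94 log units; beyond the scatter), so the group on this saturated chain carbon bound to an aromatic carbon can shift the number beyond the scatter. The entering group brings an aromatic ring and a hydrogen-bond donor that the leaving group lacks. Nothing available explains the gain. Still open, as far as these compounds go, is whether the ring, its nitrogen or the amine hydrogen carries the step, and how benzylamino or ((pyridin-3-yl)methyl)amino would read here.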